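A few compounds are considered here, and "the series" means these few. Any claim that something is new, unique, unknown or untested is made for them only; others in the source may bear on it.

Series notes. Two compounds have been run in a functional assay on SR cells (Homo sapiens) for inhibition, read by sulforhodamine B assay, with a stated time of 48 h (a higher number here means a weaker inhibitor of growth, a lower number a stronger inhibitor of growth), so far. Compound 1 `O=C(Nc1cccc(-n2cc(-c3ccncc3)c(-c3ccc(Cl)c(O)c3)n2)c1)Nc1ccc(Cl)c(Cl)c1` gives 15000 nM in this assay. Compound 2 `COc1cc(-c2nn(-c3cccc(NC(=O)c4cccc(C(F)(F)F)c4)c3)cc2-c2ccncc2)ccc1Cl` gives 4590 nM in this assay, the lower of the two numbers, and its gap to compound 1 lies beyond the usual scatter of repeated measurements. Going by the values given here, no pair of measured compounds differs in a single place, so no measured step is available to lean on.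

Compound 3 `COc1cc(-c2nn(-c3cccc(NC(=O)c4ccccc4)c3)cc2-c2ccncc2)ccc1Cl` is the next candidate, not yet run. It differs from compound 2 in one place: hydrogen in place of trifluoromethyl on an aromatic carbon. Among the compounds with values here, with no comparable step in the measured set, the expectation rests on the change alone. The step from compound 2 to compound 3 in this assay is expected to be a 1.5-fold higher number from compound 2 to compound 3 (0.18 log units; within the scatter), a modest rise that may not clear the scatter. Compound 3 is therefore estimated at 7000 nM in this assay, within a range of 2500 nM to 20000 nM.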

Compound 3, concentration for total growth inhibition: > 100000 nM
Compound 3 was reported as a limit; the forecaster's own chance of this, stated with the estimate: 5%; at least 14-fold (1.15 log units) between middle value and limit.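

Going by these compounds alone, replacing 3-(trifluoromethyl)phenyl with phenyl gives the first single-place comparison, and in this assay the change is an at least 21-fold higher number from compound 2 to compound 3 (1.33 log units; beyond the scatter), so this aromatic carbon is not indifferent to what it carries. Compound 3 stands at a limit of the assay, not at a number: the limit of > 100000 nM in this assay, at which 1 of the 3 values shown sits.

As far as these compounds go, the printed step therefore fixes the direction and a minimum size, while its true size stays unknown. The compounds shown leave open whether trifluoromethyl is specifically required on this aromatic carbon, or whether a methyl, a nitrile or a carboxylic acid there would also hold the growth inhibition seen with compound 2. They also leave open whether the same change would carry the same weight on the core of compound 1, which differs from compound 2 in more than one place.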